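Replacing one substituted ring by another on a shared core

A few compounds are considered here, and "the series" means these few. Any claim that something is new, unique, unknown or untested is made for them only; others in the source may bear on it.

Measured compounds:
Compound 1 `CSc1cc(C)nc(NC(=S)NC(=O)c2c(-c3ccc(Cl)cc3Cl)noc2C)n1`: 27.4%
Compound 2 `Cc1onc(-c2ccc(Cl)cc2Cl)c1C(=O)/N=c1/nc2nc(Cl)cc(C)n2s1`: 25.8%

In a functional assay on the whole organism (strain L.) for inhibition, with Echinochloa crus-galli as the target, with a stated time of 72 h, tested at 10 mg/L (a higher number here means more inhibition of growth at the concentration tested, a lower number less inhibition of growth), compound 1 gives 27.4%, and compound 2 gives 25.8%. The two numbers differ by less than the usual scatter, so compound 1 stands at the same level as compound 2 and neither can be called the more active one. Compound 2 differs from compound 1 in several places at once, so it gives no guidance on any single change.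

Compound 3 `COc1cc(OC)nc(NC(=S)NC(=O)c2c(-c3ccc(Cl)cc3Cl)noc2C)n1` is not yet measured. It differs from compound 1 in one place: 4,6-dimethoxypyrimidin-2-yl in place of 4-methyl-6-(methylsulfanyl)pyrimidin-2-yl on an amide-type nitrogen. Going by the values given here, the shared core is kept; only this ring changes. Among the compounds with values here, nothing among the measured compounds shows what such a swap does, so no direction can be read off. The step of a number 0.4 percentage points lower from compound 1 to compound 3 (within the scatter) is expected to stay within the scatter. Compound 3 is estimated to give 27%, with a range from 8% to 50%.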

Compound 3, percent growth inhibition at one concentration: 21.8%
Compound 3: the middle estimate sits 5.2 percentage points above what was measured; measured number inside the range.
By their numbers in this assay, from the lowest: compounds 3, 2 and 1 (each within the scatter of the next).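

In this assay, going by these compounds alone, exchanging the substituted ring on an amide-type nitrogen gives a number 5.6 percentage points lower from compound 1 to compound 3 (within the scatter), the first comparison here in which only one place differs. At this position, the two substituted rings therefore stand at the same level, and neither can be ranked above the other, even though one carries a methylsulfanyl group and a methyl group and the other two methoxy groups. No measurement available here explains this result.

On these data alone, what a ring bearing an amine or a longer chain such as butoxy would do on this nitrogen remains open. As far as these compounds go, it also remains open whether any replacement at this position can move growth inhibition by more than the usual scatter.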